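The source may hold more compounds than are shown below. What is called first, only, known or untested is meant among the compounds shown, and "the series" means these compounds.

Measured in a functional assay on HCT-116 cells (Homo sapiens) for cytotoxicity, read by MTT assay, with a stated time of 72 h; on this read-out lower numbers stand for stronger inhibition and higher numbers for weaker inhibition:
- Compound 1 `Nc1ccccc1NC(=O)c1ccc(NC(=S)NCc2ccc(Cl)nc2)cc1`: 6100 nM
- Compound 2 `Nc1ccccc1NC(=O)c1ccc(NC(=S)NCc2cncc(F)c2)cc1`: 15000 nM
- Compound 3 `Nc1ccccc1NC(=O)c1ccc(NC(=S)NCc2cncc(Br)c2)cc1`: 9200 nM

Compound 3 cannot be separated from the other two. The gaps are a 1.5-fold higher number from compound 1 to compound 3 (0.18 log units; within the scatter) and a 1.6-fold lower number from compound 2 to compound 3 (0.21 log units; within the scatter). Only a 2.5-fold higher number from compound 1 to compound 2 (0.39 log units; beyond the scatter) goes beyond the scatter, and it is modest.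

Compound 4 `Cc1ccc(CNC(=S)Nc2ccc(C(=O)Nc3ccccc3N)cc2)cn1` carries 6-methylpyridin-3-yl in place of 5-bromopyridin-3-yl on a saturated chain carbon bound to an amide-type nitrogen. Among the measured compounds shown here, no measured compound carries this methyl group, so those three steps offer only indirect guidance. All are small swaps of the pyridine group, so no step beyond the scatter is expected in this assay. The expected step is a 1.0-fold lower number from compound 3 to compound 4 (0.01 log units; within the scatter). For compound 4 the estimated value is 9000 nM, with an expected range of 4500 nM to 18000 nM.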

Compound 4, half-maximal inhibitory concentration: 11000 nM
Estimate against measurement, compound 4: 1.2-fold (0.09 log units) below; the range from low to high includes it.
By their numbers in this assay, from the lowest: compounds 1, 3, 4 and 2 (each within the scatter of the next, the first and the last beyond it).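

In this assay a methyl group on the pyridine gives a result that cannot be told apart from any of the halogen-bearing compounds, since every step to compound 4 lies within the scatter (a 1.2-fold higher number from compound 3 to compound 4 (0.08 log units; within the scatter); a 1.4-fold lower number from compound 2 to compound 4 (0.13 log units; within the scatter); a 1.8-fold higher number from compound 1 to compound 4 (0.26 log units; within the scatter)). The pyridine at this place therefore accepts a carbon group as well as a halogen, with no resolvable gain or loss. No measured evidence accounts for this result.

Still open, going by these compounds, is whether an amine, a carboxylic acid or a longer chain on this pyridine would shift the number beyond the scatter.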